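A few compounds are considered here, and "the series" means these few. Any claim that something is new, unique, unknown or untested is made for them only; others in the source may bear on it.

In a functional assay on IMR-32 cells (Homo sapiens) for antiproliferative activity, read by MTT assay (on this read-out lower numbers stand for stronger inhibition and higher numbers for weaker inhibition), three related compounds have been measured so far. Compound 1 `CC1(C)CCc2cc(C(=O)/C=C/c3ccc(OCc4cn(-c5ccc(Br)cc5)nn4)cc3)c(O)cc2O1` gives 69400 nM and compound 3 `CC1(C)CCc2c(ccc(C(=O)/C=C/c3ccc(OCc4cn(-c5ccc(Br)cc5)nn4)cc3)c2O)O1` gives 117000 nM, two numbers that lie within the usual scatter of each other. Compound 2 `Cc1ccc(-n2cc(COc3ccc(/C=C/C(=O)c4cc5c(cc4O)OC(C)(C)CC5)cc3)nn2)cc1Br` is reported as "not active" (no number reported), with no number attached. Compound 3 therefore stands level with compound 1 on the numbers available. Compound 4 `CCCCCCCCn1cc(COc2ccc(/C=C/C(=O)c3ccc4c(c3O)CCC(C)(C)O4)cc2)nn1` keeps the rest of compound 3 but carries octyl in place of 4-bromophenyl on an aromatic nitrogen. For the measured compounds named here, no measured pair shows such a swap, so no step beyond the scatter is expected in this assay, in either direction. The expected change is a 1.5-fold lower number from compound 3 to compound 4 (0.17 log units; within the scatter). For compound 4 the estimated value is 80000 nM, within a range of 25000 nM to 200000 nM.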

Compound 4, half-maximal inhibitory concentration: "not active" (no number reported)
Compound 4 has no reported number here, so the estimate cannot be set against anything.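

For the compounds shown here, compound 4 has no reported number, so no step between compound 3 and compound 4 can be read. Nothing shown here accounts for this result. Going by these compounds, what octyl in place of 4-bromophenyl does to activity remains open.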